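The compounds below may be only part of what the source reports. "The series", "measured", "known", "first", "only" and "open" are said of these compounds alone.

Measured compounds:
compound 1 `O=C(Nc1cccc(-c2ccc(-c3ccccc3)cc2)c1)C(Cl)Cl` — 10900 nM
compound 2 `CC(C)Oc1ccc(-c2cc(NC(=O)C(Cl)Cl)cc(-c3ccc(OC(C)C)cc3)c2)cc1` — 2860 nM
compound 3 `CC(C)c1ccc(-c2cc(NC(=O)C(Cl)Cl)cc(-c3ccc(C(C)C)cc3)c2)cc1` — 24800 nM

The three compounds share a dichloroacetamide on an anilide core and were examined in a functional assay on NCI-H460 cells (Homo sapiens) for cytotoxicity, read by MTT assay, with a stated time of 68 h; on this read-out higher numbers stand for weaker inhibition and lower numbers for stronger inhibition. Compound 1 carries a single extended aryl arm on the core and gives 10900 nM, which places it second highest of the three numbers. Compound 3, with two isopropyl-bearing aryl arms, gives 24800 nM, a higher number than compound 1 and beyond the usual scatter. Compound 2, with two isopropoxy-bearing aryl arms, gives 2860 nM, a lower number than compound 1, again beyond the scatter. No pair among these three differs in only one place, so the step sizes between them cannot be attributed to a single change.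

Compound 4 `O=C(Nc1cccc(-c2ccccc2)c1)C(Cl)Cl` is the not-yet-measured partner of compound 1. The change is hydrogen in place of phenyl on an aromatic carbon. With the outer phenyl gone, the molecule is smaller than any of the measured three, and nothing among them shows what a trimming of this kind does. Compound 1 is itself a weak inhibitor, so the expected step is a modest one toward a higher number, of the size a 1.8-fold higher number from compound 1 to compound 4 (0.26 log units; within the scatter). Compound 4 is therefore expected to give about 20000 nM, within a range from 7000 nM to 60000 nM.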

Compound 4, half-maximal inhibitory concentration: 20200 nM
Compound 4: the middle estimate sits 1.0-fold (0.00 log units) below what was measured; measured number inside the range.
By their numbers in this assay, from the lowest: compound 2; then compounds 1, 4 and 3 (each within the scatter of the next, the first and the last beyond it).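

In this assay, within the data shown here, compound 1 and compound 4 form the first pair that differs in one place, and hydrogen in place of phenyl on an aromatic carbon, para to a large group, gives a 1.9-fold higher number from compound 1 to compound 4 (0.27 log units; within the scatter). This step lies within the scatter, so the two compounds cannot be told apart on this read-out, and the phenyl with its 6 heavy atoms can leave this position without a step that this assay can resolve. No measurement here offers an explanation for this result.

The compounds shown leave open whether a group of another kind at this position, such as an amine or a carboxylic acid, would give a step beyond the scatter, since only phenyl and hydrogen have been compared here. From the compounds shown here alone, compound 2 and compound 3 each differ from compound 1 and from compound 4 in more than one place, so it also remains open how their second aryl arm and their isopropoxy or isopropyl groups each bear on their values.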